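Lengthening the amine alkyl chain in a benzyl-bearing analogue

A few compounds are considered here, and "the series" means these few. Any claim that something is new, unique, unknown or untested is made for them only; others in the source may bear on it.

Of the compounds shown here, three built on the same core have been tested in an assay on isolated protein for inhibition of Amine oxidase [flavin-containing] B (Homo sapiens), read by fluorescence, with a stated time of 30 min; a lower number here means a stronger inhibitor, a higher number a weaker inhibitor. Compound 1 `COc1cc2c(cc1OC)C(=O)/C(=C/c1ccc(CN(C)C)c(O)c1)CO2` gives 882 nM and compound 2 `CCN(CC)Cc1ccc(/C=C2\COc3cc(OC)c(OC)cc3C2=O)cc1O` gives 2430 nM, a step of a 2.8-fold higher number from compound 1 to compound 2 (0.44 log units; beyond the scatter). Compound 3 `COc1cc2c(cc1OC)C(=O)/C(=C/c1ccc(CN(C)Cc3ccccc3)c(O)c1)CO2` gives 1150 nM, the second highest of the three numbers, and the step of a 1.3-fold higher number from compound 1 to compound 3 (0.12 log units; within the scatter) is small, while a 2.1-fold lower number from compound 2 to compound 3 (0.32 log units; beyond the scatter) is modest. Compound 4 `CCN(Cc1ccccc1)Cc1ccc(/C=C2\COc3cc(OC)c(OC)cc3C2=O)cc1O` is not yet measured; it differs from compound 3 by methyl in place of hydrogen on a saturated chain carbon bound to an amine nitrogen. For the measured compounds named here, the closest precedent is the move from dimethylamino to diethylamino, a 2.8-fold higher number from compound 1 to compound 2 (0.44 log units; beyond the scatter), which weakened inhibition. A smaller rise is therefore expected for compound 4, namely a 1.7-fold higher number from compound 3 to compound 4 (0.24 log units; within the scatter). Compound 4 is estimated at 2000 nM, with a range from 1000 nM to 4000 nM.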

Compound 4, half-maximal inhibitory concentration: 1720 nM
Compound 4: middle estimate off by 1.2-fold (0.07 log units), on the high side, and the stated range covers the measured number.
By their numbers in this assay, from the lowest: compounds 1, 3, 4 and 2 (each within the scatter of the next, the first and the last beyond it).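

Lengthening methyl to ethyl on the amine of the benzyl-bearing analogue gives a step within the scatter (a 1.5-fold higher number from compound 3 to compound 4 (0.17 log units; within the scatter)), whereas changing both methyl groups of the dimethylamino compound to ethyl gave a step beyond it (a 2.8-fold higher number from compound 1 to compound 2 (0.44 log units; beyond the scatter)). Compound 4 also stays within the scatter of the other two amines (a 1.4-fold lower number from compound 2 to compound 4 (0.15 log units; within the scatter); a 2.0-fold higher number from compound 1 to compound 4 (0.29 log units; within the scatter)), so these data cannot order it against either. Nothing available explains these small steps.

As far as these compounds go, whether a propyl or longer chain on the amine would stay within the scatter remains open. So does the effect of replacing the amine with a carboxylic acid.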